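A Branched Chain in Place of Cyclohexyl

This account rests on a few compounds, and the source may have more. Where it says the series, first, only, none or still open, it means among the compounds named here.

Among the measured compounds shown here, compound 1 `CC(C)c1onc(-c2c(Cl)cccc2Cl)c1COc1ccc(-c2nc3ccc(C(=O)O)cc3n2C2CC2)cc1` is the only member of this small group with a result: in an assay on isolated protein for agonist activity at Bile acid receptor (Homo sapiens), read by TR-FRET (a higher number here means that more compound is needed for the effect, a lower number that less compound is needed), compound 1 gives 117 nM. Compound 2 `CC(C)c1onc(-c2c(Cl)cccc2Cl)c1COc1ccc(-c2nc3ccc(C(=O)O)cc3n2C2CCC2)cc1` shares the same core, and in this assay compound 2 gives "not determined" (no result reported). Compound 3 `CC(C)c1onc(-c2c(Cl)cccc2Cl)c1COc1ccc(-c2nc3ccc(C(=O)O)cc3n2C2CCCCC2)cc1` likewise shares the core, and in this assay compound 3 gives "not determined" (no result reported), so compound 3 stands without any number of its own. Compound 4 `CCCC(CCC)n1c(-c2ccc(OCc3c(-c4c(Cl)cccc4Cl)noc3C(C)C)cc2)nc2ccc(C(=O)O)cc21` differs from compound 3 in a single place (1-propylbutyl in place of cyclohexyl on an aromatic nitrogen). For the measured compounds named here, no step between measured compounds is available, so the size and direction of this change cannot be read from the data; a shift either way is possible, and one within the scatter is as plausible as one beyond it. Compound 4 is expected to give about 150 nM in this assay, within a range from 40 nM to 600 nM.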

Compound 4, half-maximal effective concentration: 30.3 nM
Compound 4: the middle estimate sits 5.0-fold (0.69 log units) above what was measured; the measured number lies below the stated range.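

In this assay, swapping the small cyclopropyl ring on the aromatic nitrogen for the open-chain 1-propylbutyl gives a 3.9-fold lower number from compound 1 to compound 4 (0.59 log units; beyond the scatter), a modest step beyond the scatter. This position therefore accepts a branched chain with no ring, and with that chain less compound is needed for the effect. Nothing measured here gives a reason for this shift. The steps from compound 2 and compound 3 to compound 4 cannot be read, so cyclobutyl and cyclohexyl remain unplaced against the chain. Also open, from the compounds shown here alone, is whether a shorter branched chain such as 1-ethylpropyl, or a chain carrying an amine, would behave the same way.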